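Hydroxy to nitro on the aromatic ring

This account rests on a few compounds, and the source may have more. Where it says the series, first, only, none or still open, it means among the compounds named here.

Values so far in a functional assay on MCF7 cells (Homo sapiens) for cytotoxicity, read by sulforhodamine B assay; a lower number here means a stronger inhibitor of growth, a higher number a weaker inhibitor of growth
Compound 1 (`CC1=CC[C@@H]([C@@](C)(O)CCCC(C)(C)NC(=S)NN)CC1`) gives 15300 nM
Compound 2 (`CC1=CC[C@@H]([C@@](C)(O)CCCC(C)(C)NC(=S)N/N=C\c2ccc(O)cc2)CC1`) gives 6230 nM

Compound 2 holds the lower of the two numbers (6230 nM), which makes it the stronger growth inhibitor of the pair. Compound 3 (`CC1=CC[C@@H]([C@@](C)(O)CCCC(C)(C)NC(=S)N/N=C\c2ccc([N+](=O)[O-])cc2)CC1`) differs from it in one place (nitro in place of hydroxy on an aromatic carbon): nitro in place of hydroxy on an aromatic carbon, para to a large group. Among the compounds with values here, only one measured step bears on this, and only loosely. That step (a 2.5-fold lower number from compound 1 to compound 2 (0.39 log units; beyond the scatter)) was modest and brought in the whole aromatic ring with its hydroxy. Within the data shown here, no measured pair shows what a swap on that ring does, so the direction stays open. In this assay a small step is therefore expected, probably no larger than that modest one. The estimated step (a 1.1-fold lower number from compound 2 to compound 3 (0.05 log units; within the scatter)) is close to none. For compound 3 the expected value is 5500 nM (estimated range 2200 nM to 14000 nM).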

Compound 3, concentration for 50% growth inhibition: 17700 nM
Compound 3: the middle estimate sits 3.2-fold (0.51 log units) below what was measured; measured number above the stated range.
By their numbers in this assay, from the lowest: compound 2; then compounds 1 and 3 (each within the scatter of the next).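

Swapping 4-hydroxyphenyl for 4-nitrophenyl is not a neutral change in this assay: it gives a 2.8-fold higher number from compound 2 to compound 3 (0.45 log units; beyond the scatter), so growth inhibition at this position on the aromatic ring depends on the group it carries. Compound 3 keeps the aromatic ring, yet its number lies within the usual scatter of that of compound 1, so the ring alone does not bring the lower number seen with compound 2. Nothing measured here explains the difference between hydroxy and nitro.

Still open, as far as these compounds go, is whether an amine at this position would behave more like hydroxy or more like nitro. A methoxy group would also be informative, since it keeps the oxygen of hydroxy but not its hydrogen.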